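From dichlorophenyl to methoxyphenyl at the assay limit

The compounds below may be only part of what the source reports. "The series", "measured", "known", "first", "only" and "open" are said of these compounds alone.

Within the data shown here, compound 1 `COc1cc(-c2ncnn2-c2ccc(Cl)cc2Cl)cc(OC)c1OC` is the starting point, and its only reading comes from a functional assay on Jurkat cells (Homo sapiens) for antiproliferative activity, read by MTT assay, with a stated time of 72 h; on this read-out higher numbers stand for weaker inhibition and lower numbers for stronger inhibition. There compound 1 gives > 10000 nM, which is a limit and not a number. Compound 2 `COc1cc(-n2ncnc2-c2ccc(Cl)cc2)cc(OC)c1OC` gives > 10000 nM, also a limit. Compound 3 `COc1cc(-n2ncnc2-c2ccccc2)cc(OC)c1OC` gives > 10000 nM, again a limit. The whole picture so far is the limit of > 10000 nM in this assay, at which 3 of the 3 values shown sit, so compound 1 shares its place with the other two and none of them has a readable value.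

Compound 4 `COc1ccc(-n2ncnc2-c2cc(OC)c(OC)c(OC)c2)cc1` is the next to be measured. It replaces the 2,4-dichlorophenyl of compound 1 with 4-methoxyphenyl on an aromatic nitrogen: 4-methoxyphenyl in place of 2,4-dichlorophenyl on an aromatic nitrogen.

Among the measured compounds shown here, only one measured step bears on this change, and it concerns chloro on an aromatic carbon: a step that the two limits leave unreadable from compound 2 to compound 3. That step has no readable size, so it offers no guide to the size of the new one. For the measured compounds named here, no measured compound carries the 4-methoxyphenyl group. Any readable change from compound 1 can only be towards stronger inhibition, and compound 4 could also stay at the limit. The expected step, a rough estimate, is an at least 33-fold lower number from compound 1 to compound 4 (1.52 log units; beyond the scatter). For compound 4 the estimated value is 300 nM, with an expected range from 20 nM to 10000 nM.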

Compound 4, half-maximal inhibitory concentration: 93 nM
Beside the measured number, compound 4's estimate is 3.2-fold (0.51 log units) above it; low and high end bracket the measured number.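

In this assay, replacing 2,4-dichlorophenyl with 4-methoxyphenyl on the aromatic nitrogen gives an at least 100-fold lower number from compound 1 to compound 4 (2.03 log units; beyond the scatter), so the group at this position can decide whether inhibition is seen at all in this series. The size of this step is only a lower bound, since the reading for compound 1 is a limit and not a number, and the true gap could be wider. Compound 4 is also the first compound here with a readable value, which gives later changes a number to be compared against, whereas the others all stay at the same limit: the limit of > 10000 nM in this assay, at which 3 of the 4 values shown sit.

This single step removes two chloro groups and brings in a methoxy group at once, so the compounds shown cannot say whether losing the chlorines, gaining the methoxy or both produce the gain, and compounds 2 and 3 differ from compound 4 in more than one place, so they cannot settle it. Also open, from the compounds shown here alone, is how the reading would move with an ethoxy or a dimethylamino group in place of the methoxy group of compound 4.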